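This account rests on a few compounds, and the source may have more. Where it says the series, first, only, none or still open, it means among the compounds named here.

In a functional assay on A549 cells (Homo sapiens) for cytotoxicity, read by sulforhodamine B assay (on this read-out higher numbers stand for weaker inhibition and lower numbers for stronger inhibition), compound 1 `COc1ccc(Cn2c3c(c4ccccc4c2=O)CCOc2ccccc2-3)cc1` gives 11000 nM. For the measured compounds named here, compound 2 `COc1ccc(Cn2c(-c3ccccc3O)c(Br)c3ccccc3c2=O)cc1` gives 71300 nM in this assay, the higher of the two numbers measured so far; its gap to compound 1 lies beyond the usual scatter, so compound 2 is the weaker inhibitor of the pair. Compound 3 `COc1ccc(Cn2c(-c3ccccc3O)c(Br)c3cc(C)ccc3c2=O)cc1` has not been tested. Compared with compound 2 it carries methyl in place of hydrogen on an aromatic carbon. Going by the values given here, no measured pair shows this change, and it is expected to give no step beyond the scatter, a 1.2-fold lower number from compound 2 to compound 3 (0.07 log units; within the scatter). Compound 3 is therefore estimated at 60000 nM in this assay, with a range from 20000 nM to 180000 nM.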

Compound 3, half-maximal inhibitory concentration: 53000 nM
The estimate for compound 3 lay 1.1-fold (0.05 log units) above the measured number, within the range that was stated.
By their numbers in this assay, from the lowest: compound 1; then compounds 3 and 2 (each within the scatter of the next).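

In this assay, methyl in place of hydrogen on this aromatic carbon gives a 1.3-fold lower number from compound 2 to compound 3 (0.13 log units; within the scatter) and so leaves the number unchanged within the scatter. For the compounds shown here, this pair is the first to test this position, and it shows that one added carbon here is tolerated, though it brings no measurable gain. Nothing available explains this result. As far as these compounds go, whether a larger group on the same carbon, such as an ethyl, a methoxy or an amine, would shift the number remains open. So does whether methyl would do the same on the core of compound 1.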